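Moving a chlorine on a triazole-linked sulfonamide series

The source may hold more compounds than are shown below. What is called first, only, known or untested is meant among the compounds shown, and "the series" means these compounds.

Of the compounds shown here, three sharing a uracil-derived sulfonamide core have been tested in a functional assay on SGC-7901 cells (Homo sapiens) for antiproliferative activity, read by MTT assay, with a stated time of 24 h; a lower number here means a stronger inhibitor, a higher number a weaker inhibitor. Compound 1, `O=c1[nH]cc(S(=O)(=O)Nc2ccccc2-c2cn(-c3ccccc3Cl)nn2)c(=O)[nH]1`, gives 6520 nM. Compound 2, `O=c1[nH]cc(S(=O)(=O)Nc2ccccc2-c2cn(-c3cccc(Cl)c3)nn2)c(=O)[nH]1`, gives 2270 nM. Compound 3, `O=c1[nH]cc(S(=O)(=O)Nc2ccc(-c3cn(-c4ccccc4Cl)nn3)cc2)c(=O)[nH]1`, gives 2680 nM.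

Compound 1 and compound 2 differ in one place only: 3-chlorophenyl in place of 2-chlorophenyl on an aromatic nitrogen. This single change produced a 2.9-fold lower number from compound 1 to compound 2 (0.46 log units; beyond the scatter). The values of compound 2 and compound 3 lie close together, so nothing can be said about their order. Compound 3 and compound 1 have different cores, the sulfonamide nitrogen and the triazole sitting on different positions of the central benzene ring, but the difference between the two cores is not broken down here; their values simply show a lower number for compound 3 than for compound 1.

Compound 4, `O=c1[nH]cc(S(=O)(=O)Nc2ccc(-c3cn(-c4cccc(Cl)c4)nn3)cc2)c(=O)[nH]1`, has not yet been measured in this assay. It stands to compound 3 exactly as compound 2 stands to compound 1: 3-chlorophenyl in place of 2-chlorophenyl on an aromatic nitrogen. The surroundings of the change are the same in both pairs, so this is the same change on the other core. Because the step of a 2.9-fold lower number from compound 1 to compound 2 (0.46 log units; beyond the scatter) was beyond the scatter, a step of similar direction is expected here, though the second core gives no independent check, so the expected step of a 2.4-fold lower number from compound 3 to compound 4 (0.39 log units; beyond the scatter) is taken somewhat cautiously. Compound 4 is therefore estimated at 1100 nM in this assay, expected to fall between 500 nM and 2500 nM.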

Compound 4, half-maximal inhibitory concentration: 2460 nM
The estimate for compound 4 lay 2.2-fold (0.35 log units) below the measured number, within the range that was stated.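

On the core of compound 3, 3-chlorophenyl in place of 2-chlorophenyl gives a 1.1-fold lower number from compound 3 to compound 4 (0.04 log units; within the scatter) in this assay, so on this core the two chlorine placements cannot be told apart. Setting this step beside the one on the core of compound 1 does not prove that the two cores respond differently, since the gap between the steps is no larger than two such steps could show by scatter alone: the same change on two cores in this assay, a 2.9-fold lower number (0.46 log units; beyond the scatter) from compound 1 to compound 2 and a 1.1-fold lower number (0.04 log units; within the scatter) from compound 3 to compound 4, 2.6-fold (0.42 log units) apart, within the scatter of two such steps Nor does it show that the change carries over, as the only step beyond the scatter comes from the core of compound 1, and with a single pair on each core the question stays undecided.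

These four compounds all carry a chlorine on the phenyl ring attached to the triazole nitrogen, so they leave open what an unsubstituted phenyl, or a methoxy group, a nitrile or an amine in place of the chlorine, would do on either core. A further matched pair on each core, with one of these groups, could show whether a change on this ring gives steps that agree from one core to the other.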